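Replacing a nitrophenyl arm with pyridine in a triazole amide

This account rests on a few compounds, and the source may have more. Where it says the series, first, only, none or still open, it means among the compounds named here.

Measured so far:
- compound 1, `O=C(Cn1cc(-c2ccc([N+](=O)[O-])cc2)nn1)Nc1nccs1`, gives 1040 nM in a functional assay on BMDM cells (Mus musculus, strain C57BL/6) for inhibition, with a stated time of 2 days; on this read-out higher numbers stand for weaker inhibition and lower numbers for stronger inhibition
- compound 2, `O=C(Cn1cc(-c2ccc([N+](=O)[O-])cc2)nn1)Nc1nc2ccccc2s1`, gives 3280 nM
- compound 3, `COC(=O)c1ccc(-c2cn(CC(=O)Nc3nc4ccccc4s3)nn2)cc1`, gives only a limit of the assay, > 30000 nM

Among the numbers that are plain values, compound 2 stands highest, and the step of a 3.2-fold higher number from compound 1 to compound 2 (0.50 log units; beyond the scatter) is modest. Compound 4, `O=C(Cn1cc(-c2ccncc2)nn1)Nc1nc2ccccc2s1`, differs from compound 2 by pyridin-4-yl in place of 4-nitrophenyl on an aromatic carbon. The most relevant measured step is an at least 9.1-fold higher number from compound 2 to compound 3 (0.96 log units; beyond the scatter), which also removed the nitro group and ended at a limit (the limit of > 30000 nM in this assay, at which 1 of the 3 values shown sits). Since compound 4 likewise loses the nitro group, a weakening of at least a modest size is expected, with a real chance that only a limit is reported. Compound 4 is therefore estimated at 12000 nM, between 3500 nM and 40000 nM, meaning an expected step of a 3.7-fold higher number from compound 2 to compound 4 (0.56 log units; beyond the scatter).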

Compound 4, half-maximal inhibitory concentration: 50 nM
The estimate for compound 4 lay 240-fold (2.38 log units) above the measured number, outside the stated range (below it).
By their numbers in this assay, from the lowest: compound 4; then compound 1; then compound 2. At a limit, above all of these: compound 3.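

In this assay, the aromatic carbon carrying the 4-nitrophenyl group turns out to tolerate loss of the nitro group, and the change to pyridin-4-yl gives a 66-fold lower number from compound 2 to compound 4 (1.82 log units; beyond the scatter). Compound 3, which has methoxycarbonyl in place of nitro, stands at a limit of the assay, > 30000 nM, so losing the nitro group can go either way. Nothing measured here explains the gain. From the compounds shown here alone, whether pyridin-3-yl or a phenyl ring bearing an amine would match pyridin-4-yl remains open. So does whether the same change would help with the 1,3-thiazol-2-yl group of compound 1.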